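The source may report more compounds than this note shows. Statements on the series, on what has been measured and on what is new or still open speak of the compounds shown alone.

Measured so far:
- compound 1, `Cc1cccc(Cn2c(CN3CCN(C(=O)c4ccc(C(F)(F)F)cc4)CC3)nc3ccccc32)c1`, 22.9%
- compound 2, `Cc1ccc(Cn2c(CN3CCN(C(=O)C4CC4)CC3)nc3ccccc32)cc1`, 51.5%
- compound 3, `O=C(C1CC1)N1CCN(Cc2nc3ccccc3n2Cc2ccc(F)cc2)CC1`, 32.7%

In an assay on isolated protein for inhibition of aldehyde dehydrogenase 1A1 (Homo sapiens), read by spectrophotometry, tested at 10 uM (on this read-out higher numbers stand for more inhibition at the one concentration tested (going by the name of the read-out) and lower numbers for less inhibition), compound 1 gives the lowest of the three numbers. Compound 3 stands nearest to it, within the usual scatter of such readings, while compound 2 lies well beyond the scatter above it. Compound 4, `CCC(=O)N1CCN(Cc2nc3ccccc3n2Cc2cccc(C)c2)CC1`, differs from compound 1 in one place: ethyl in place of 4-(trifluoromethyl)phenyl on a carbonyl carbon.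

For the measured compounds named here, no measured step touches the amide side of the shared core directly. Going by the values given here, the only step that differs in one place, a number 18.8 percentage points lower from compound 2 to compound 3 (beyond the scatter), concerns the substituent on the other aromatic ring and so does not bear on this change. What the values of compound 2 and compound 3 show is that both compounds, each carrying a small cycloalkyl group on the carbonyl carbon, read higher than compound 1, though each also differs from compound 1 in a second place. On that thin basis, a modest upward step a number 13.1 percentage points higher from compound 1 to compound 4 (beyond the scatter) is expected for compound 4, which is estimated at 36%, with a range from 20% to 55%.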

Compound 4, a percentage reported as inhibition, at one concentration (the size of the read-out at that concentration, not a potency): 85.1%
Estimate against measurement, compound 4: 49.1 percentage points below; the whole stated range lies below it.
By their numbers in this assay, from the lowest: compounds 1 and 3 (each within the scatter of the next); then compound 2; then compound 4.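

In this assay, for the compounds shown here, the swap of 4-(trifluoromethyl)phenyl for ethyl on the carbonyl carbon is the first change read directly at this position, and it gives a number 62.2 percentage points higher from compound 1 to compound 4 (beyond the scatter) in a single step. The only earlier step, a number 18.8 percentage points lower from compound 2 to compound 3 (beyond the scatter), lay elsewhere on the molecule and was much smaller, so this carbonyl substituent now stands out as the place where the read-out moves most among the compounds shown. No measurement offered here accounts for the size of this step.

The compounds shown leave open whether a plain phenyl, a methyl or a longer chain such as butyl on the same carbonyl carbon would read like ethyl or like 4-(trifluoromethyl)phenyl. On these data alone, it also remains open how ethyl would read alongside the fluoro group of compound 3.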